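This account rests on a few compounds, and the source may have more. Where it says the series, first, only, none or still open, it means among the compounds named here.

In an assay for inhibition of Tryptophan 2,3-dioxygenase (Homo sapiens), with stated times of 10 min and 60 min, tested at 100 uM (a lower number here means a weaker effect, a higher number a stronger effect of the compound at the concentration tested), compound 2, `FC(F)(F)c1cc(NC[C@H]2CCCN2)c2cn[nH]c2c1`, gives 84%, which is the lowest of the three numbers recorded. Compound 1, `COc1cc(CNc2cc(Br)cc3[nH]ncc23)c([N+](=O)[O-])cc1OC`, gives 95% in this assay, a number higher than that of compound 2 by more than the usual scatter, and compound 3, `CS(=O)(=O)c1ccc(CNc2cc(C(F)(F)F)cc3[nH]ncc23)c([N+](=O)O)c1`, gives 98% in this assay, higher still and again beyond the scatter. Both of the higher numbers belong to compounds in which an aromatic ring stands on the saturated chain carbon bound to the ring nitrogen, whereas compound 2 carries pyrrolidin-2-yl there.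

Compound 4, `FC(F)(F)c1cc(NCc2cccc(Br)c2)c2cn[nH]c2c1`, has not been measured in this assay. It differs from compound 2 in one place: 3-bromophenyl in place of pyrrolidin-2-yl on a saturated chain carbon bound to a nitrogen on an aromatic ring. Among the compounds with values here, no step between two measured compounds that differ in exactly this way is available, so the expectation for compound 4 rests on the gap between compound 2 and the two aryl-bearing compounds 1 and 3. On that basis an upward step from compound 2 to compound 4 in this assay is expected, of a size beyond the scatter, namely a number 8 percentage points higher from compound 2 to compound 4 (within the scatter). Compound 4 is therefore estimated to give 92% in this assay, within a range from 80% to 99%.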

Compound 4, a percentage reported as inhibition, at one concentration (the size of the read-out at that concentration, not a potency): 84%
Beside the measured number, compound 4's estimate is 8 percentage points above it; low and high end bracket the measured number.
By their numbers in this assay, from the lowest: compounds 2 and 4 (each within the scatter of the next); then compounds 1 and 3 (each within the scatter of the next).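

With the rest of the molecule held constant, the exchange of pyrrolidin-2-yl for 3-bromophenyl on a saturated chain carbon bound to a nitrogen on an aromatic ring gives no change at the digits printed from compound 2 to compound 4 (within the scatter) in this assay. Within the data shown here, this is the only direct comparison at this place, and it shows that the read-out at the single concentration tested does not separate these two groups, although the exchange removes a non-aromatic ring with its hydrogen-bond donor, hydrogen-bond acceptor and defined stereocentre and brings in an aromatic ring of carbon with a bromine. An aromatic ring at this place is thus not enough on its own to give the higher numbers of compounds 1 and 3, and no measurement at hand explains the outcome.

Those two compounds differ from compound 2 and compound 4 in more than one place, so what sets their numbers apart remains unresolved. Also open, from the compounds shown here alone, is how this place responds to other groups, such as unsubstituted phenyl, piperidin-2-yl or an open-chain amine, and whether compound 2 and compound 4 would still match in a measure of potency rather than at one concentration.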